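Trifluoromethoxy for Trifluoromethyl on a Hydroxy-Bearing Core

This account rests on a few compounds, and the source may have more. Where it says the series, first, only, none or still open, it means among the compounds named here.

Compound 1 `FC(F)(F)c1ccc(-c2ccc(-c3ccc(-c4nc5ccccc5[nH]4)cc3)cc2)cc1` and compound 2 `FC(F)(F)Oc1ccc(-c2ccc(-c3ccc(-c4nc5ccccc5[nH]4)cc3)cc2)cc1` share one core and differ only in one spot: trifluoromethoxy in place of trifluoromethyl on an aromatic carbon. In a functional assay on MCF7 cells (Homo sapiens) for inhibition, read by sulforhodamine B assay (on this read-out lower numbers stand for stronger inhibition of growth and higher numbers for weaker inhibition of growth), compound 1 gives 41400 nM, while compound 2 gives 38400 nM, so that a 1.1-fold lower number from compound 1 to compound 2 (0.03 log units; within the scatter). Compound 3 `Oc1cccc2[nH]c(-c3ccc(-c4ccc(-c5ccc(C(F)(F)F)cc5)cc4)cc3)nc12` keeps the trifluoromethyl end of compound 1 but carries a changed core, the difference being (hydroxy in place of hydrogen on an aromatic carbon). In this assay compound 3 gives 2310 nM, which means an 18-fold lower number from compound 1 to compound 3 (1.25 log units; beyond the scatter). Compound 4 `Oc1cccc2[nH]c(-c3ccc(-c4ccc(-c5ccc(OC(F)(F)F)cc5)cc4)cc3)nc12` has not been measured yet; it relates to compound 3 as compound 2 relates to compound 1, through (trifluoromethoxy in place of trifluoromethyl on an aromatic carbon). The surroundings of the altered position read the same way in both pairs, so this is the same change carried onto the hydroxy-bearing core. A step of about the same small size is expected here, namely a 1.1-fold lower number from compound 3 to compound 4 (0.02 log units; within the scatter), because a 1.1-fold lower number from compound 1 to compound 2 (0.03 log units; within the scatter). Compound 4 is therefore expected to give about 2200 nM, with a likely range from 1100 nM to 4400 nM.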

Compound 4, concentration for 50% growth inhibition: 2210 nM
Beside the measured number, compound 4's estimate is 1.0-fold (0.00 log units) below it; the measured number falls inside the stated range.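

Swapping trifluoromethyl for trifluoromethoxy on the hydroxy-bearing core leaves the result in this assay essentially unchanged, with a 1.0-fold lower number from compound 3 to compound 4 (0.02 log units; within the scatter), and this agrees with what the same swap did on the core without the hydroxy group: the same change on two cores in this assay, a 1.1-fold lower number (0.03 log units; within the scatter) from compound 1 to compound 2 and a 1.0-fold lower number (0.02 log units; within the scatter) from compound 3 to compound 4, 1.0-fold (0.01 log units) apart, within the scatter of two such steps Seen from the other side, adding the hydroxy group to the trifluoromethoxy compound gives a 17-fold lower number from compound 2 to compound 4 (1.24 log units; beyond the scatter), a large step that matches the one seen with the trifluoromethyl end: the same change on two cores in this assay, an 18-fold lower number (1.25 log units; beyond the scatter) from compound 1 to compound 3 and a 17-fold lower number (1.24 log units; beyond the scatter) from compound 2 to compound 4, 1.0-fold (0.01 log units) apart, within the scatter of two such steps Across these four compounds, each of the two changes therefore carries over from one partner to the other, but this rests on only two cores in a single assay and does not show that the swap would stay this small on any other core, nor does it explain why the hydroxy group matters so much.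

Going by these compounds, it remains open whether an amine or a carboxylic acid in place of the hydroxy group would give a similarly large step. On these data alone, it is also open whether a longer chain in place of trifluoromethoxy would stay as close to trifluoromethyl.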